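Methoxy to chloro on the hydroxamic acid series

The source may hold more compounds than are shown below. What is called first, only, known or untested is meant among the compounds shown, and "the series" means these compounds.

Of the compounds shown here, two have numbers so far. In a functional assay on HeLa cells (Homo sapiens) for antiproliferative activity, read by MTT assay, with a stated time of 48 h (on this read-out higher numbers stand for weaker inhibition and lower numbers for stronger inhibition), compound 1 `COc1cccc2ccc(CNCc3ccc(/C=C/C(=O)NO)cc3)nc12` gives 3330 nM as its half-maximal inhibitory concentration, and compound 2 `COc1ccc2nc(CNCc3ccc(/C=C/C(=O)NO)cc3)ccc2c1` gives 2680 nM on the same read-out. These two values lie within the scatter of each other, so compound 2 stands level with compound 1 and neither can be ranked ahead.

The next compound is compound 3 `O=C(/C=C/c1ccc(CNCc2ccc3cc(Cl)ccc3n2)cc1)NO` with chloro in place of methoxy on an aromatic carbon of compound 2 chloro in place of methoxy on an aromatic carbon and the rest of the structure unchanged. Among the compounds with values here, no measured pair shows what this exchange does in this assay and the data offer no direct precedent for it. Within the data shown here, the only guide is the level of compound 2 at 2680 nM in this narrow set. No shift beyond the scatter is expected, and no direction is favoured: the estimated change is a 1.1-fold lower number from compound 2 to compound 3 (0.03 log units; within the scatter) for now. For compound 3 the estimated value is 2500 nM with an expected range from 800 nM to 7000 nM in this assay.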

Compound 3, half-maximal inhibitory concentration: 3030 nM
The estimate for compound 3 lay 1.2-fold (0.08 log units) below the measured number; the range from low to high includes it.
By their numbers in this assay, from the lowest: compounds 2, 3 and 1 (each within the scatter of the next).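

In this assay, within the data shown here, the exchange of chloro for methoxy gives a 1.1-fold higher number from compound 2 to compound 3 (0.05 log units; within the scatter) and is the first reading of any exchange at this position. At this place, on an aromatic carbon of a six-membered aromatic ring of carbon only, part of a fused or bridged system of two rings, meta to a fused ring and para to a fused ring, the assay does not separate methoxy, with its 2 heavy atoms and 1 hydrogen-bond acceptor, from chloro, with 1 heavy atom and no acceptor. Nothing measured on these compounds accounts for this result, so it stands as an observation on this one pair only.

Still open, going by these compounds, is whether any group at this place moves the number beyond the scatter, since one level pair says nothing about an amine, a carboxylic acid or a longer chain such as ethoxy there. Also open, on these data alone, is whether chloro in place of methoxy reads the same on compound 1, where the methoxy stands elsewhere on the core, and whether the level seen here holds beyond this single cell line.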